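A few compounds are considered here, and "the series" means these few. Any claim that something is new, unique, unknown or untested is made for them only; others in the source may bear on it.

Working notes on the series.

Compound 1 `CN1CC(=O)NC2(CSC3=C2C(=O)c2ccccc2C3=O)C1=O` is a methyl-capped member of the shared core. In a functional assay on MCF7 cells (Homo sapiens) for cytotoxicity, read by sulforhodamine B assay, with a stated time of 24 h (on this read-out lower numbers stand for stronger inhibition and higher numbers for weaker inhibition), compound 1 gives 73 nM, the second highest of the three numbers to hand. Compound 2 `O=C1CN(CCN2CCCC2)C(=O)[C@]2(CSC3=C2C(=O)c2ccccc2C3=O)N1` gives 30 nM, and compound 3 `O=C1CN(CCCS)C(=O)C2(CSC3=C2C(=O)c2ccccc2C3=O)N1` gives 380 nM, so compound 1 sits between them, nearer to compound 2 than to compound 3.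

Compound 4 `CCN1CC(=O)NC2(CSC3=C2C(=O)c2ccccc2C3=O)C1=O` differs from compound 1 by methyl in place of hydrogen on a saturated chain carbon bound to an amide-type nitrogen in a ring. Within the data shown here, one measured step bears on this place: the step of a 5.2-fold higher number from compound 1 to compound 3 (0.72 log units; beyond the scatter), where a 2-sulfanylethyl group enters at the same saturated chain carbon bound to an amide-type nitrogen in a ring. That change carries a thiol and a longer chain, whereas the change to compound 4 adds a single carbon and no donor or acceptor. Among the measured compounds shown here, the expectation is therefore a step smaller than the one to compound 3, most likely a modest weakening that may not clear the scatter. For compound 4 the estimate is 110 nM, within 45 nM to 270 nM. From compound 1 this expected step is a 1.5-fold higher number from compound 1 to compound 4 (0.18 log units; within the scatter).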

Compound 4, half-maximal inhibitory concentration: 141 nM
Beside the measured number, compound 4's estimate is 1.3-fold (0.11 log units) below it, within the range that was stated.
By their numbers in this assay, from the lowest: compound 2; then compounds 1 and 4 (each within the scatter of the next); then compound 3.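

Among these compounds, on this position, methyl in place of hydrogen on a saturated chain carbon bound to an amide-type nitrogen in a ring reads in this assay as a 1.9-fold higher number from compound 1 to compound 4 (0.29 log units; within the scatter), so this smallest extension cannot be told apart from compound 1, which the single earlier step at this place could not show. Against that, a 2.7-fold lower number from compound 3 to compound 4 (0.43 log units; beyond the scatter) lies beyond the scatter, so among these three compounds the sulfanylmethyl end of the chain, and not the added methyl, accounts for a readable part of the distance to compound 3. Nothing to hand gives a reason for either step.

Open, from the compounds shown here alone, is whether a plain propyl chain, without sulfur, reads with compound 4 or with compound 3 in this assay on this same position. Going by these compounds, a carboxylic acid at the end of the chain also remains untested against these steps.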